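Swapping One Small Group on Compound 3

The source may report more compounds than this note shows. Statements on the series, on what has been measured and on what is new or still open speak of the compounds shown alone.

Values in an ADME assay on L1210/0 cells (Mus musculus) for cytotoxicity, with a stated time of 48 h; a lower number here means a stronger inhibitor, a higher number a weaker inhibitor:
- compound 1 `O=c1[nH]cnc2c1nnn2C1C[C@H](CO)[C@@H](CO)[C@@H]1CO`: > 200000 nM
- compound 2 `O=C(/C=C/c1cc(=O)[nH]c(=O)n1COCCO)c1ccccc1`: 43300 nM
- compound 3 `O=c1[nH]c(=O)n([C@H]2C[C@H](O)[C@@H](CO)O2)cc1/C=N/O`: 15500 nM

The entry for compound 1, > 200000 nM, is a limit of this assay and not a number, as the limit of > 200000 nM in this assay, at which 1 of the 3 values shown sits, records.

Only two of the three entries are therefore true numbers. Of these two, compound 3 holds the lower one at 15500 nM. Its nearest neighbour is compound 2 at 43300 nM, and that gap lies beyond the usual scatter of repeated measurements.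

The next compound to be tested is compound 4 `N#CSc1cn([C@H]2C[C@H](O)[C@@H](CO)O2)c(=O)[nH]c1=O`. It keeps the rest of compound 3 and changes one group on an aromatic carbon, where cyanosulfanyl takes the place of a group with no common name: a group of 3 heavy atoms (1 carbon, 1 nitrogen, 1 sulfur; no ring) in place of a group of 3 heavy atoms (1 carbon, 1 nitrogen, 1 oxygen; no ring), on an aromatic carbon.

Going by the values given here, no two measured compounds differ in only one place, so the data offer no direct guide to the size of this change. The expectation starts from compound 3 at 15500 nM and stays cautious. A modest shift towards a lower number is expected in this assay, although a result within the scatter remains quite possible. The estimated change is a 1.9-fold lower number from compound 3 to compound 4 (0.29 log units; within the scatter).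

For compound 4 the estimated value is 8000 nM, with an expected range from 1500 nM to 40000 nM.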

Compound 4, half-maximal inhibitory concentration: 78900 nM
Compound 4: middle estimate off by 9.9-fold (0.99 log units), on the low side, outside the stated range (above it).
By their numbers in this assay, from the lowest: compound 3; then compounds 2 and 4 (each within the scatter of the next). At a limit, above all of these: compound 1.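

Going by these compounds alone, the swap to cyanosulfanyl on the aromatic carbon gives a 5.1-fold higher number from compound 3 to compound 4 (0.71 log units; beyond the scatter) in this assay and so provides the first direct reading of this position, which no earlier pair of compounds could offer. The step shows that the assay responds to a change at this carbon even when the group that enters has the same count of heavy atoms as the group that leaves, and here the change goes towards weaker inhibition. The group that leaves has a double bond and a hydrogen-bond donor, while the group that enters has a triple bond and no such donor, but nothing measured here tells which of these differences matters.

The compounds shown leave open how this position would respond to other groups, such as an amine, a carboxylic acid or a longer chain, and whether the sulfur or the nitrile part of cyanosulfanyl goes with the step. They also leave open whether the same swap would give a step of similar size on another core, since compound 1 and compound 2 each differ from compound 3 in more than one place.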